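This account rests on a few compounds, and the source may have more. Where it says the series, first, only, none or still open, it means among the compounds named here.

Going by the values given here, compound 2 `CCCCCCCCc1ccc(C(=O)C[C@H]2C[C@H](CO)CN2)cc1` stands higher of the two numbers measured so far: in a functional assay on FL5.12 cells (Mus musculus), read by flow cytometry, with a stated time of 3 h, tested at 2.5 uM (on this read-out higher numbers stand for a stronger effect at the one concentration tested and lower numbers for a weaker effect), compound 2 gives 44%, while compound 1 `CCCCCCCCc1ccc(C(=O)C[C@@H]2CCCN2)cc1` gives 28%, the step being a number 16 percentage points higher from compound 1 to compound 2 (beyond the scatter). Compound 3 `CCCCCCCCc1ccc(C(=O)CC[C@H]2C[C@H](CO)CN2)cc1` is not yet measured; it differs from compound 2 by a group of 8 heavy atoms (6 carbon, 1 nitrogen, 1 oxygen; one five-membered non-aromatic ring with 1 hetero atom) in place of a group of 7 heavy atoms (5 carbon, 1 nitrogen, 1 oxygen; one five-membered non-aromatic ring with 1 hetero atom), on a saturated chain carbon bound to a carbonyl carbon. Among the compounds with values here, the one measured step, from compound 1 to compound 2, concerned a different change at the same place and offers little guidance here, so no step beyond the scatter is expected. Compound 3 is therefore expected to give about 42% in this assay, between 25% and 60%. The expected step is a number 2 percentage points lower from compound 2 to compound 3 (within the scatter).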

Compound 3, a percentage reported as activity, at one concentration (the size of the read-out at that concentration, not a potency): 8%
For compound 3 the middle estimate is 34 percentage points above the measured one, and the stated range ends above it.
By their numbers in this assay, from the lowest: compound 3; then compound 1; then compound 2.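

In this assay, this position proves sensitive to a small change: the group of 8 heavy atoms in place of the group of 7 heavy atoms gives a number 36 percentage points lower from compound 2 to compound 3 (beyond the scatter). Against the group of 5 heavy atoms, the same group gives a number 20 percentage points lower from compound 1 to compound 3 (beyond the scatter), so among these compounds a higher heavy-atom count at this place does not go with a steady rise or fall in the read-out. Nothing measured here explains the drop. Going by these compounds, what a longer chain or a carboxylic acid at this place would give stays open.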